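The compounds below may be only part of what the source reports. "The series", "measured", "known", "first", "only" and "open" are said of these compounds alone.

Working notes on the series. Compound 1 is `CCCCCCCCOC(=O)CCC(=O)N1CCN(CCCOc2cc3c(Nc4ccc(F)c(Cl)c4)ncnc3cc2OC)CC1`; in a functional assay on A549 cells (Homo sapiens) for cytotoxicity, read by MTT assay, with a stated time of 24 h, tested at 80 uM (a lower number here means a stronger effect, a higher number a weaker effect of the compound at the concentration tested), compound 1 gives 21.7%. Compound 2 is `CCCCCCCCCCOC(=O)CCC(=O)N1CCN(CCCOc2cc3c(Nc4ccc(F)c(Cl)c4)ncnc3cc2OC)CC1`; in this assay compound 2 gives 2%. For the measured compounds named here, compound 2 therefore stands lowest of the two numbers measured so far, and its one neighbour is reached by the step of a number 19.7 percentage points lower from compound 1 to compound 2 (beyond the scatter), which lies beyond the scatter. Compound 3 is `CCCCCCCCCCCCOC(=O)CCC(=O)N1CCN(CCCOc2cc3c(Nc4ccc(F)c(Cl)c4)ncnc3cc2OC)CC1`. Relative to compound 2 the change is ethyl in place of hydrogen on a saturated chain carbon, ten or more bonds along the chain from an oxygen next to a carbonyl group. Going by the values given here, the only measured step that bears on this change is a number 19.7 percentage points lower from compound 1 to compound 2 (beyond the scatter), the same exchange of ethyl for hydrogen on a saturated chain carbon, there eight bonds along the chain from an oxygen next to a carbonyl group; it lowered the read-out by a modest amount. Whether the same direction continues cannot be told from a single step, and compound 2 already reads close to the bottom of the scale, so there is little room for a further drop of that size. The step from compound 2 to compound 3 is expected to be a number 2 percentage points higher from compound 2 to compound 3 (within the scatter), within the scatter. For compound 3 the expected value in this assay is 4%, with a range from 0% to 15%.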

Compound 3, a percentage reported as activity, at one concentration (the size of the read-out at that concentration, not a potency): 2.3%
Compound 3: the middle estimate sits 1.7 percentage points above what was measured; low and high end bracket the measured number.
By their numbers in this assay, from the lowest: compounds 2 and 3 (each within the scatter of the next); then compound 1.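

In this assay, for the compounds shown here, ethyl in place of hydrogen on a saturated chain carbon, ten or more bonds along the chain from an oxygen next to a carbonyl group, gives a number 0.3 percentage points higher from compound 2 to compound 3 (within the scatter) and so leaves compounds 2 and 3 indistinguishable, unlike the same exchange eight bonds along the chain, the only earlier step, which lay beyond the scatter. Butyl in place of hydrogen eight bonds along the chain gives a number 19.4 percentage points lower from compound 1 to compound 3 (beyond the scatter) and so keeps compound 3 apart from compound 1, which shows that the separation from compound 1 holds for both of the two longest chains, while the numbers for compounds 2 and 3 lie so close to the bottom of the scale that any further effect of chain length cannot be read at this concentration. No measurement at hand gives a reason for this result.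

The compounds shown leave open whether a still longer chain, a branched chain, or a chain ending in an amine or a carboxylic acid would read like compounds 2 and 3. They also leave open whether compounds 2 and 3 would separate at a lower concentration.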